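A few compounds are considered here, and "the series" means these few. Any claim that something is new, unique, unknown or untested is made for them only; others in the source may bear on it.

Measured so far:
compound 1 `CCCCNc1oc2c(C)ncc(CO)c2c1Nc1ccccn1`: 9380 nM
compound 2 `CCCCCNc1oc2c(C)ncc(CO)c2c1Nc1cccc(F)c1`: 370 nM

Both numbers come from a functional assay on HEK293 cells for agonist activity at Toll-like receptor 8 (Homo sapiens), read by reporter gene assay; on this read-out higher numbers stand for an effect only at larger amounts of compound and lower numbers for an effect already at smaller amounts. Compound 1 holds the higher of the two numbers; compound 2 sits well below it, and that gap lies beyond the scatter. Compound 3 `CCCC(C)Nc1oc2c(C)ncc(CO)c2c1Nc1ccccn1` is not yet measured. Against compound 1 it carries methyl in place of hydrogen on a saturated chain carbon bound to a nitrogen on an aromatic ring and a saturated chain carbon. Among the measured compounds shown here, no measured pair isolates this change, so there is nothing to scale it from. The expectation is a step from compound 1 to compound 3 of a 1.2-fold lower number from compound 1 to compound 3 (0.07 log units; within the scatter), not clearly beyond the scatter in either direction. Compound 3 is estimated at 8000 nM, with a range from 3000 nM to 25000 nM.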

Compound 3, half-maximal effective concentration: 9010 nM
Beside the measured number, compound 3's estimate is 1.1-fold (0.05 log units) below it, within the range that was stated.
By their numbers in this assay, from the lowest: compound 2; then compounds 3 and 1 (each within the scatter of the next).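

In this assay, methyl in place of hydrogen on the saturated chain carbon bound to the ring-attached nitrogen gives a 1.0-fold lower number from compound 1 to compound 3 (0.02 log units; within the scatter). Among the compounds shown here, on the core of compound 1, butyl to 1-methylbutyl therefore leaves the read-out unchanged within the scatter, the first single-place information at this position. No independent measurement bears on why this change leaves the number in place.

From the compounds shown here alone, whether ethyl or hydroxymethyl on this same carbon would behave like methyl remains open. Compound 2 differs from compound 1 in two places, so neither change can be assigned its share of that gap.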